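A few compounds are considered here, and "the series" means these few. Any claim that something is new, unique, unknown or untested is made for them only; others in the source may bear on it.

Of the compounds shown here, three sharing one core have been tested in an ADME assay on HEL cells (Homo sapiens) for cytotoxicity, with a stated time of 3 days; on this read-out higher numbers stand for lower toxicity in this test and lower numbers for higher toxicity in this test. Compound 1 `CC1(Cc2ccccc2)OS(=O)(=O)C=C1OCc1ccccc1` gives > 400000 nM, which is a limit of the assay rather than a measured number. Compound 2 `CCC1(Cc2ccccc2)OS(=O)(=O)C=C1OCC#N` likewise gives > 400000 nM, again a limit. Compound 3 `CC(C)CC1(Cc2ccccc2)OS(=O)(=O)C=C1OCc1ccccc1` gives >= 80000 nM, also a limit. Compound 2 therefore stands only at a limit, and the two further values shown are limits as well. Among the measured compounds shown here, the one step between measured compounds that differ in a single place, a step that the two limits leave unreadable from compound 1 to compound 3, has no readable size: both of its ends are limits.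

Compound 4 `CCC1(Cc2ccccc2)OS(=O)(=O)C=C1OCC1CCCCC1` has not yet been measured; it differs from compound 2 by cyclohexyl in place of cyano on a saturated chain carbon bound to an oxygen on an unsaturated carbon. For the measured compounds named here, no measured step covers this exchange, so the expectation rests on the pattern that every value so far is a limit: two values sit at the limit of > 400000 nM in this assay, at which 2 of the 3 values shown sit, and one at the limit of >= 80000 nM in this assay, at which 1 of the 3 values shown sits. The step from compound 2 to compound 4 is therefore expected to be an at least 1.1-fold lower number from compound 2 to compound 4 (0.05 log units; that floor lies within the scatter), nothing beyond the scatter. Compound 4 is estimated at 350000 nM, within 80000 nM to 400000 nM, most likely reported once more only as a limit.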

Compound 4, minimum cytotoxic concentration: >= 200000 nM
Compound 4: no number, only a limit; the forecaster's own chance of this, stated with the estimate: 75%; the middle value is on the limit's open side.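

In this assay compound 4 gives >= 200000 nM, which is a limit and not a number. Among the compounds shown here, compound 2 also stands only at a limit, so no step between these two compounds can be read. The compounds shown leave open what actual minimum cytotoxic concentration any of them has.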